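A few compounds are considered here, and "the series" means these few. Any claim that something is new, unique, unknown or untested is made for them only; others in the source may bear on it.

In a functional assay on MGC-803 cells (Homo sapiens) for inhibition, read by CCK-8 assay, with a stated time of 48 h (a higher number here means a weaker inhibitor, a lower number a stronger inhibitor), compound 1 `COc1ccc(CN(C(=O)CSC(=S)N2CCN(C)CC2)c2cc(OC)c(OC)c(OC)c2)cc1` gives 1280 nM, compound 2 `COc1ccc(CN(C(=O)CSC(=S)N2CCc3cc(OC)ccc32)c2cc(OC)c(OC)c(OC)c2)cc1` gives 11700 nM and compound 3 `COc1cc(N(Cc2ccc(C)cc2)C(=O)CSC(=S)N2CCN(C(=O)OC(C)(C)C)CC2)cc(OC)c1OC` gives 16700 nM. Compound 3 thus lies within the scatter of compound 2 and is clearly weaker than compound 1. Compound 4 `COc1ccc(CN(C(=O)CSC(=S)N2CCN(C(=O)OC(C)(C)C)CC2)c2cc(OC)c(OC)c(OC)c2)cc1Br` differs from compound 3 at a saturated chain carbon bound to an amide-type nitrogen: 3-bromo-4-methoxyphenyl in place of 4-methylphenyl on a saturated chain carbon bound to an amide-type nitrogen. Among the compounds with values here, the only measured step, a 9.1-fold higher number from compound 1 to compound 2 (0.96 log units; beyond the scatter), was modest and arose at a thiocarbonyl carbon, so it does not speak to this change. Within the data shown here, no measured step covers this place, so no shift beyond the scatter is expected in this assay. The estimated step is a 1.4-fold lower number from compound 3 to compound 4 (0.14 log units; within the scatter). For compound 4 the estimate is 12000 nM, with an expected range of 4000 nM to 32000 nM.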

Compound 4, half-maximal inhibitory concentration: 3710 nM
Beside the measured number, compound 4's estimate is 3.2-fold (0.51 log units) above it, outside the stated range (below it).
By their numbers in this assay, from the lowest: compound 1; then compound 4; then compounds 2 and 3 (each within the scatter of the next).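

In this assay, the group on a saturated chain carbon bound to an amide-type nitrogen proves able to move the number, with 3-bromo-4-methoxyphenyl in place of 4-methylphenyl giving a 4.5-fold lower number from compound 3 to compound 4 (0.65 log units; beyond the scatter). Within the data shown here, this is the first measured sign that this place matters, whereas the earlier step concerned only the thiocarbonyl carbon. Nothing available explains the shift. Because the change adds bromine and replaces methyl with methoxy together, the compounds shown cannot separate the two contributions. From the compounds shown here alone, whether a chlorine or an amine could stand in place of the bromine also remains open.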